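Pendant aryl change on the shared core: toward compound 3

The compounds below may be only part of what the source reports. "The series", "measured", "known", "first", "only" and "open" are said of these compounds alone.

Two compounds of this series have numbers in a functional assay on HT-29 cells (Homo sapiens) for inhibition, read by sulforhodamine B assay, with a stated time of 48 h, tested at 10 uM; a lower number here means less inhibition, a higher number more inhibition at the concentration tested (going by the name of the read-out). Compound 1 `Clc1ccc(-c2cn3ccnc3c(-c3ccc4ncn(C5CCCCC5)c4c3)n2)cc1` gives 16.4%. Within the data shown here, compound 2 `Brc1ccc(-c2cn3ccnc3c(-c3ccc4ncn(C5CCCCC5)c4c3)n2)cc1` gives 20.9%, and the one step measured so far, a number 4.5 percentage points higher from compound 1 to compound 2 (within the scatter), leaves the two compounds within the scatter of each other; neither number can be called the higher, and the two are level at the concentration tested.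

Compound 3 `COc1ccccc1-c1cn2ccnc2c(-c2ccc3ncn(C4CCCCC4)c3c2)n1` carries the difference (2-methoxyphenyl in place of 4-bromophenyl on an aromatic carbon). Among the measured compounds shown here, no measured step bears directly on this change: the single step known, from one halogen to another on the same ring, is a different kind of exchange and was itself within the scatter, so it says nothing about a methoxy group placed on a different carbon of that ring. The expectation therefore rests on the observation that the shared core with a substituted phenyl has so far given only low numbers in this assay, and no step beyond the scatter is expected, with a number 2.9 percentage points lower from compound 2 to compound 3 (within the scatter) as the expected step. Compound 3 is estimated at 18%, with a range from 4% to 36%.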

Compound 3, a percentage reported as inhibition, at one concentration (the size of the read-out at that concentration, not a potency): 11.1%
The estimate for compound 3 lay 6.9 percentage points above the measured number, within the range that was stated.
By their numbers in this assay, from the lowest: compounds 3, 1 and 2 (each within the scatter of the next).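

In this assay, exchanging 4-bromophenyl for 2-methoxyphenyl gives a number 9.8 percentage points lower from compound 2 to compound 3 (within the scatter) and exchanging 4-chlorophenyl for the same group gives a number 5.3 percentage points lower from compound 1 to compound 3 (within the scatter), so neither exchange separates compound 3 from the halogen-bearing compounds. The earlier step tested only bromo in place of chloro, whereas these two steps replace the halogen-bearing phenyl at this aromatic carbon of the shared core with a phenyl carrying a methoxy group, and compounds 1, 2 and 3 remain level at the concentration tested. No measurement at hand offers an explanation for these numbers and the steps are read here only as numbers.

Because each step changes both the substituent and its place on the phenyl ring, these compounds cannot show which of the two matters, and 4-methoxyphenyl would separate them. On these data alone, it also remains open whether a phenyl ring bearing an amine or a carboxylic acid, or a pyridine in place of the phenyl, would give a step beyond the scatter at this carbon.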